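Semicarbazone series: swapping an aryl group for an alkyl chain

The source may report more compounds than this note shows. Statements on the series, on what has been measured and on what is new or still open speak of the compounds shown alone.

Measured compounds:
Compound 1, `CNC(=S)Nc1ccc(S(=O)(=O)Nc2nc3ccc(OC)cc3s2)cc1`, in a functional assay on the whole organism with Mus musculus as the target, in the maximal electroshock model, with a stated time of 0.5 h (a lower number here means that less compound is needed, a higher number that more compound is needed for the effect), compound 1 gives 300 mg/kg.
Compound 2, `CCOc1ccc(NC(=O)N/N=C(\C)c2ccc(O)cc2)cc1`, in this assay compound 2 gives 100 mg/kg.
Compound 3, `CCOc1ccc(NC(=O)N/N=C(\C)c2ccc(Cl)cc2)cc1`, in this assay compound 3 gives 300 mg/kg.

Compound 3 sits level with compound 1 at the digits shown; together they are the highest of the three numbers, so both need more compound than compound 2 for the same effect. For the measured compounds named here, the one step measured so far, a 3.0-fold higher number from compound 2 to compound 3 (0.48 log units; beyond the scatter), is a modest one and concerns only the substituent on the phenyl ring.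

Compound 4, `CCOc1ccc(NC(=O)N/N=C(\C)CC(C)C)cc1`, has not yet been measured. It differs from compound 3 in one place: isobutyl in place of 4-chlorophenyl on a carbon with a double bond to nitrogen. No measured step bears on this kind of change, since the only step shown keeps the phenyl ring and alters its substituent. With nothing to point either way, no step beyond the scatter is expected, so for compound 4 the expected step is no change at the digits printed from compound 3 to compound 4 (within the scatter). Compound 4 is therefore estimated at 300 mg/kg, within a range from 100 mg/kg to 1000 mg/kg.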

Compound 4, minimum effective dose: 100 mg/kg
For compound 4 the middle estimate is 3.0-fold (0.48 log units) above the measured one; measured number inside the range.
By their numbers in this assay, from the lowest: compounds 2 and 4 (each within the scatter of the next); then compounds 1 and 3 (each within the scatter of the next).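

In this assay, the carbon with a double bond to nitrogen does not need an aromatic ring for the effect: replacing 4-chlorophenyl with isobutyl gives a 3.0-fold lower number from compound 3 to compound 4 (0.48 log units; beyond the scatter), and replacing 4-hydroxyphenyl with isobutyl gives no change at the digits printed from compound 2 to compound 4 (within the scatter). The earlier step changed only a substituent on the ring, whereas these two steps remove the whole ring, and the open-chain compound 4 still matches the better of the two ring compounds at the digits printed. No measurement here explains why the isobutyl chain is tolerated.

On these data alone, whether a shorter chain such as ethyl or a longer chain such as n-hexyl would do as well at this carbon remains open. So does the effect of a saturated ring such as cyclohexyl, or of an amine carried on the chain.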